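A few compounds are considered here, and "the series" means these few. Any claim that something is new, unique, unknown or untested is made for them only; others in the source may bear on it.

The study concerns agonists of the thromboxane receptor, tested in a functional assay on a cell-free system (plasma) for agonist activity at thromboxane A2 receptor (Homo sapiens); a lower number here means a stronger inhibitor, a higher number a weaker inhibitor. Compound 1 `O=C(O)COC/C=C1/C[C@H]2C[C@@H](O)[C@H](/C=N/NC(=O)Nc3cccc(Cl)c3)[C@H]2C1` is the stronger of the two measured compounds: in this assay compound 1 gives 180 nM. Compound 2 `O=C(O)COC/C=C1\C[C@H]2C[C@@H](O)[C@H](/C=N/NC(=O)Nc3ccccc3)[C@H]2C1` carries an unsubstituted phenyl group on the semicarbazone and has the other arrangement at the exocyclic double bond; in this assay compound 2 gives 6000 nM, the highest number among the two compounds measured, and the gap to compound 1 lies beyond the usual scatter. Because compound 1 and compound 2 differ in two places at once, the two values alone cannot say how much of that gap belongs to the aromatic substituent.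

Compound 3 `O=C(O)COC/C=C1\C[C@H]2C[C@@H](O)[C@H](/C=N/NC(=O)Nc3cccc(Cl)c3)[C@H]2C1` has not yet been measured. It keeps the double bond geometry of compound 2 and differs from it in one place: chloro in place of hydrogen on an aromatic carbon. Among the measured compounds shown here, as the only measured compound with this chloro group, compound 1, stands at 180 nM, the step is expected to lower the number, though by less than the whole gap between compound 1 and compound 2. The change from compound 2 to compound 3 is estimated at a 4.0-fold lower number from compound 2 to compound 3 (0.60 log units; beyond the scatter). For compound 3 in this assay the expected value is 1500 nM, with a range from 300 nM to 6000 nM.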

Compound 3, half-maximal inhibitory concentration: 1600 nM
Compound 3: middle estimate off by 1.1-fold (0.03 log units), on the low side; the range from low to high includes it.
By their numbers in this assay, from the lowest: compound 1; then compound 3; then compound 2.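

With the double bond kept as in compound 2, replacing phenyl with 3-chlorophenyl gives, in this assay, a 3.8-fold lower number from compound 2 to compound 3 (0.57 log units; beyond the scatter), so chloro at this aromatic carbon has a measurable effect without any change in geometry. Changing only the exocyclic double bond gives an 8.9-fold higher number from compound 1 to compound 3 (0.95 log units; beyond the scatter), which shows that the gap between compound 1 and compound 2 has two separable parts, each beyond the scatter. The comparison isolates configuration from every other structural feature, as the atoms and bonds stay the same: the fact that compounds 1 and 3 differ only in the configuration as drawn

The compounds shown leave open whether chloro changes the number by a similar amount when the double bond is arranged as in compound 1, and so whether the two changes simply add. They also leave open how a fluoro, methyl or methoxy group would compare with chloro at this aromatic carbon, and what would follow from replacing the carboxylic acid with an amide or a tetrazole.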